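Urea series at the cytotoxicity limit: nitro for trifluoromethyl

This account rests on a few compounds, and the source may have more. Where it says the series, first, only, none or still open, it means among the compounds named here.

Compound 1 `COc1ccc(NC(=O)Nc2cc(C)nc3ccccc23)cc1`: in an ADME assay on Raji cells (Homo sapiens) for cytotoxicity, with a stated time of 72 h (on this read-out higher numbers stand for an effect only at larger amounts of compound and lower numbers for an effect already at smaller amounts), compound 1 gives > 25000 nM, a limit of the assay.
Compound 2 `Cc1cc(NC(=O)Nc2ncccc2C)c2ccccc2n1`: in this assay compound 2 gives > 25000 nM, a limit of the assay.
Compound 3 `Cc1cc(NC(=O)Nc2ccccc2C(F)(F)F)c2ccccc2n1`: in this assay compound 3 gives > 25000 nM, a limit of the assay.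

Compound 3 therefore stands where every value shown stands, at the limit of > 25000 nM in this assay, at which 3 of the 3 values shown sit. No numbered value separates any two of these compounds, so no order among them can be read. Compound 4 `Cc1cc(NC(=O)Nc2ccccc2[N+](=O)[O-])c2ccccc2n1` is the next member and is still to be measured. It differs from compound 3 by nitro in place of trifluoromethyl on an aromatic carbon. Since all three measured compounds sit at the same limit, no step beyond the usual scatter is expected, in either direction; the step that the limit leaves unreadable from compound 3 to compound 4 is an estimate only. Compound 4 is expected to give 40000 nM, within 20000 nM to 100000 nM, most likely reported again as a limit.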

Compound 4, half-maximal effective concentration: > 25000 nM
Compound 4 ended at the assay's limit; the forecaster's own chance of this, stated with the estimate: 85%; the middle value lies beyond the limit too.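

Compound 4, like compound 3, stands at a limit of the assay, so no step between them can be read: the limit of > 25000 nM in this assay, at which 4 of the 4 values shown sit.

The compounds shown leave open how these four would rank in this assay.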